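This account rests on a few compounds, and the source may have more. Where it says the series, first, only, none or still open, it means among the compounds named here.

Measured compounds:
compound 1 `N#CN/C(=N\CCOC(=O)c1ccccc1)NCCCOc1cccc(CN2CCCCC2)c1` — 7.64
compound 2 `N#CN/C(=N\CCCNC(=O)c1ccccc1)NCCCCOc1cccc(CN2CCCCC2)c1` — 6.6

Both were tested in a functional assay on cardiac atrium for antagonist activity at histamine H2 receptor (Cavia porcellus); a lower number here means a less potent compound, a higher number a more potent compound, by a factor of ten per unit of this negative logarithm. Compound 1 gives 7.64, the higher of the two numbers; compound 2 gives 6.6, which lies beyond the scatter below compound 1. The two differ in more than one place, so no single step can be read from them.

Compound 3 `N#CN/C(=N\CCCNC(=O)CCc1ccccc1)NCCCOc1cccc(CN2CCCCC2)c1` has not yet been measured. It differs from compound 1 by ((phenethylcarbonyl)amino)methyl in place of benzoyloxy on a saturated chain carbon, two bonds along the chain from a double-bonded nitrogen. The change reaches into the same region of the molecule in which compound 2 already departs from compound 1, and compound 2 carries a group of the same kind that enters in compound 3. On that basis a loss in this assay is expected, of moderate size, with the step from compound 1 to compound 3 estimated at a number 0.64 log units lower from compound 1 to compound 3 (beyond the scatter), though the chain differences keep this uncertain. Compound 3 is therefore expected to give about 7, in the range 6.4 to 7.6.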

Compound 3, negative logarithm of the antagonist equilibrium constant: 6.07
Estimate against measurement, compound 3: 0.93 log units above; measured number outside the range, below it.
By their numbers in this assay, from the lowest: compound 3; then compound 2; then compound 1.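

In this assay, among these compounds, ((phenethylcarbonyl)amino)methyl in place of benzoyloxy on a saturated chain carbon, two bonds along the chain from a double-bonded nitrogen, gives a number 1.57 log units lower from compound 1 to compound 3 (beyond the scatter), the first change that can be read at a single place. This position is therefore sensitive to substitution on the core of compound 1, and this exchange carries a large loss. No available measurement bears on the reason for this loss.

The entering group differs from benzoyloxy in its heavy-atom count, its amide hydrogen and its chain, and this one step does not separate these differences. Also open, going by these compounds, is how this assay responds at this position to a simple amine, a carboxylic acid or a benzoylamino group on the otherwise unchanged core of compound 1.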